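A few compounds are considered here, and "the series" means these few. Any claim that something is new, unique, unknown or untested is made for them only; others in the source may bear on it.

Measured so far:
compound 1 `ClCc1cccc(Cn2cnc3c(Cl)nc(Cl)nc32)c1` gives 7940 nM
compound 2 `Nc1nc(Cl)c2ncn(Cc3ccccc3CCl)c2n1` gives 97200 nM

Both compounds carry the shared core with a benzyl group bearing a chloromethyl substituent. In a functional assay on KM12 cells (Homo sapiens) for cytotoxicity, read by sulforhodamine B assay, with a stated time of 48 h (on this read-out lower numbers stand for higher toxicity in this test and higher numbers for lower toxicity in this test), compound 2, at 97200 nM, stands highest of the two numbers; the nearest is compound 1 at 7940 nM, a gap beyond the scatter. For the measured compounds named here, no pair of measured compounds differs in one place only, so no measured step isolates a single change.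

Compound 3 `ClCc1ccccc1Cn1cnc2c(Cl)ncnc21` is the unmeasured partner of compound 2. The change is hydrogen in place of amino on an aromatic carbon, between two ring nitrogen atoms of the core. Going by the values given here, the only guide is that compound 1, which lacks the amino group, gives the lower number 7940 nM. A step of moderate size toward lower numbers in this assay is therefore expected, a 3.9-fold lower number from compound 2 to compound 3 (0.59 log units; beyond the scatter), though with wide uncertainty. For compound 3 the estimate is 25000 nM, within 6000 nM to 90000 nM.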

Compound 3, concentration lethal to 50% of the cells: 66100 nM
Compound 3: middle estimate off by 2.6-fold (0.42 log units), on the low side; the measured number falls inside the stated range.
By their numbers in this assay, from the lowest: compound 1; then compounds 3 and 2 (each within the scatter of the next).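

For the compounds shown here, this is the first one-place step measured: hydrogen in place of amino on an aromatic carbon, between two ring nitrogen atoms of the shared core, gives a 1.5-fold lower number from compound 2 to compound 3 (0.17 log units; within the scatter) in this assay and so no readable difference. For this pair, the amino group at this position is therefore not required for the number seen in this test. Going by these compounds alone, nothing measured so far offers an explanation for this result.

On these data alone, how a methylamino group, a hydroxyl group or a longer alkyl chain would read in this assay at this position remains open. Compound 1 at 7940 nM differs from compound 3 in more than one place. The measurements so far do not separate those places.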